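The compounds below may be only part of what the source reports. "The series", "measured", "known", "first", "only" and "open" are said of these compounds alone.

Compound 1 `CCOC(=O)OCC(CO)CCn1cnc2cnc(N)nc21`: > 500000 nM
Compound 2 `CCCCCOC(=O)OCC(CO)CCn1cnc2cnc(N)nc21`: > 500000 nM
Compound 3 `COC(=O)OCC(CO)CCn1cnc2cnc(N)nc21`: > 500000 nM

In a functional assay on Vero cells (Chlorocebus sabaeus) for cytotoxicity (a higher number here means that more compound is tolerated, a lower number that less compound is tolerated), compound 2 gives > 500000 nM, which is a limit of the assay and not a number. Compound 1 gives > 500000 nM in this assay, also a limit. Compound 3 gives > 500000 nM in this assay, again a limit. The next compound, compound 4 `CC(C)CCOC(=O)OCC(CO)CCn1cnc2cnc(N)nc21`, has not yet been measured. It differs from compound 2 in one place: isopropyl in place of propyl on a saturated chain carbon, two bonds along the chain from an oxygen next to a carbonyl group. The measured steps that bear on this are a step that the two limits leave unreadable from compound 1 to compound 2 and a step that the two limits leave unreadable from compound 2 to compound 3, and both stay unreadable because of the limit of > 500000 nM in this assay, at which 3 of the 3 values shown sit. No step beyond the scatter is therefore expected in this assay, and the expected step of a number no higher from compound 2 to compound 4 (the limit leaves the size open) is essentially none. Compound 4 is expected to give 500000 nM, in a range from 250000 nM to 1000000 nM, most likely as another limit.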

Compound 4, half-maximal cytotoxic concentration: 357000 nM
Estimate against measurement, compound 4: 1.4-fold (0.15 log units) above, within the range that was stated.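

In this assay, within the data shown here, compound 4 gives 357000 nM, the first real number in this set rather than a limit. That reading yields an at least 1.4-fold lower number from compound 2 to compound 4 (0.14 log units; that floor lies within the scatter), an at least 1.4-fold lower number from compound 3 to compound 4 (0.14 log units; that floor lies within the scatter) and an at least 1.4-fold lower number from compound 1 to compound 4 (0.14 log units; that floor lies within the scatter), so isopropyl in place of propyl is not shown to change how much compound is tolerated. The steps among compound 1, compound 2 and compound 3 cannot be read: the limit of > 500000 nM in this assay, at which 3 of the 4 values shown sit.

As far as these compounds go, whether a longer branched chain, an amine or a carboxylic acid at this place would give a number clearly lower stays open.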